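The compounds below may be only part of what the source reports. "The series", "measured", "known", "first", "only" and "open" are said of these compounds alone.

In an ADME assay on MT4 cells (Homo sapiens) for cytotoxicity, with a stated time of 5 days (on this read-out higher numbers stand for lower toxicity in this test and lower numbers for higher toxicity in this test), compound 2 `CC(C)(C)C#Cc1cc(N(C(=O)[C@H]2CC[C@H](C)CC2)[C@H]2CC[C@H](OC3COC3)CC2)c(C(=O)O)s1` gives 8350 nM as its value, compound 1 `CC(C)(C)C#Cc1cc(N(C(=O)[C@H]2CC[C@H](C)CC2)[C@H]2CC[C@](O)(CO[C@H]3CCOC3)CC2)c(C(=O)O)s1` gives 8980 nM and compound 3 `CC1=CC[C@H](C(=O)N(c2cc(C#CC(C)(C)C)sc2C(=O)O)[C@H]2CC[C@](O)(CO[C@H]3CCOC3)CC2)CC1` gives 12100 nM on the same read-out. These three values lie within the scatter of one another. Compound 4 `CC(C)(C)C#Cc1cc(N(C(=O)[C@H]2CC[C@H](C)CC2)[C@H]2CC[C@H](OC3CCOC3)CC2)c(C(=O)O)s1` differs from compound 2 at one place, and oxolan-3-yl in place of oxetan-3-yl on an oxygen on a saturated carbon is the whole change. Going by the values given here, no measured step covers it directly. Among the compounds with values here, the only measured step, a 1.3-fold higher number from compound 1 to compound 3 (0.13 log units; within the scatter), sits elsewhere, on a carbonyl carbon, and stays within the scatter. Compound 1 also carries oxolan-3-yl on an oxygen and gives 8980 nM within that same scatter. In this assay no step beyond the scatter is expected, and the estimated step is a 1.1-fold higher number from compound 2 to compound 4 (0.03 log units; within the scatter) with no firm direction. Compound 4 is estimated at 9000 nM with an expected range from 5000 nM to 16000 nM for now.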

Compound 4, half-maximal cytotoxic concentration: 3070 nM
Compound 4: middle estimate off by 2.9-fold (0.47 log units), on the high side, and the stated range ends above it.
By their numbers in this assay, from the lowest: compound 4; then compounds 2, 1 and 3 (each within the scatter of the next).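

In this assay the ring on this oxygen matters: oxolan-3-yl in place of oxetan-3-yl on an oxygen on a saturated carbon gives the only step shown beyond the scatter (a 2.7-fold lower number from compound 2 to compound 4 (0.43 log units; beyond the scatter)). A five-membered ring in place of a four-membered one at this place therefore moves the series toward higher toxicity in this test, if modestly. Nothing measured here accounts for the step.

As far as these compounds go, whether the shift tracks ring size or belongs to oxolan-3-yl alone stays open; oxan-4-yl or an open 2-methoxyethyl chain on the same oxygen would separate the two.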